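The source may hold more compounds than are shown below. What is called first, only, known or untested is meant among the compounds shown, and "the series" means these compounds.

Three compounds share one core and differ only in the group attached to the amide carbonyl. In a functional assay (Sus scrofa) with sulfonylurea receptors; K-ATP channels (Homo sapiens) as the target (a higher number here means a larger maximal response, a lower number a smaller maximal response), compound 1 `CC(=O)Nc1c(C(O)(C(F)(F)F)C(F)(F)F)ccc2ccccc12` gives 87%. Compound 2 `CCCC(=O)Nc1c(C(O)(C(F)(F)F)C(F)(F)F)ccc2ccccc12` gives 92%, and compound 3 `COCC(=O)Nc1c(C(O)(C(F)(F)F)C(F)(F)F)ccc2ccccc12` gives 93%. Compound 3 shows a number 6 percentage points higher from compound 1 to compound 3 (within the scatter) and a number 1 percentage points higher from compound 2 to compound 3 (within the scatter), so the three cannot be told apart. Compound 4 `N#Cc1cccc(C(=O)Nc2c(C(O)(C(F)(F)F)C(F)(F)F)ccc3ccccc23)c1` differs from compound 3 by 3-cyanophenyl in place of methoxymethyl on a carbonyl carbon. The measured steps all alter this same position and were small: a number 5 percentage points higher from compound 1 to compound 2 (within the scatter) as well. None of them brings in a ring, so the new change is larger than anything seen, and the range must be wider. Compound 4 is expected to give about 88%, between 70% and 100%. The expected step is a number 5 percentage points lower from compound 3 to compound 4 (within the scatter), none beyond the scatter.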

Compound 4, largest response reached (reported as efficacy), in percent of the reference or control that the assay uses: 96%
For compound 4 the middle estimate is 8 percentage points below the measured one, within the range that was stated.
By their numbers in this assay, from the lowest: compounds 1, 2, 3 and 4 (each within the scatter of the next).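

In this assay, the position on the carbonyl carbon takes a ring without a loss of response: 3-cyanophenyl gives a number 3 percentage points higher from compound 3 to compound 4 (within the scatter), a number 4 percentage points higher from compound 2 to compound 4 (within the scatter), and a number 9 percentage points higher from compound 1 to compound 4 (within the scatter). The earlier compounds shown here carried only open chains here, whereas these steps show that an aromatic ring and a nitrile can enter and the four compounds still cannot be told apart. Nothing available explains this result.

On these data alone, whether an amine, a carboxylic acid or an unsubstituted phenyl ring at this position would give a similar response remains open. So does what the nitrile itself contributes.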